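Arylpiperazine to benzylpiperazine: a step into unmeasured ground

This account rests on a few compounds, and the source may have more. Where it says the series, first, only, none or still open, it means among the compounds named here.

Compound 1, `N#Cc1cccc(COc2ccc(-c3cc(CN4CCN(c5ccc(C(F)(F)F)cc5)CC4)no3)cc2)c1`: 2700 nM
Compound 2, `N#Cc1cccc(COc2ccc(-c3cc(CN4CCN(c5ccc(C(F)(F)F)cn5)CC4)no3)cc2)c1`: 1300 nM

In a functional assay on Mahlavu cells (Homo sapiens) for antiproliferative activity, read by sulforhodamine B assay, with a stated time of 72 h (a higher number here means a weaker inhibitor, a lower number a stronger inhibitor), compound 2 holds the lowest of the two numbers, and its nearest neighbour is compound 1. Among the measured compounds shown here, the one measured step, a 2.1-fold lower number from compound 1 to compound 2 (0.32 log units; beyond the scatter), is modest but beyond the scatter.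

Compound 3, `N#Cc1cccc(COc2ccc(-c3cc(CN4CCN(Cc5ccc(F)cc5)CC4)no3)cc2)c1`, has not been measured. It differs from compound 2 by 4-fluorobenzyl in place of 5-(trifluoromethyl)pyridin-2-yl on an amine nitrogen in a ring. For the measured compounds named here, no measured step bears directly on this change: the step between compound 1 and compound 2 exchanges one six-membered aromatic ring for another on the same ring nitrogen, whereas here a benzyl group enters in place of an aryl group, so that step only shows how small the numbers moved when the ring nitrogen's substituent was varied. Compound 3 is therefore expected to land somewhat weaker, with a 1.9-fold higher number from compound 2 to compound 3 (0.28 log units; within the scatter) as the estimated step. The estimate for compound 3 in this assay is 2500 nM, within 700 nM to 9000 nM.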

Compound 3, half-maximal inhibitory concentration: 1500 nM
Beside the measured number, compound 3's estimate is 1.7-fold (0.22 log units) above it; the range from low to high includes it.
By their numbers in this assay, from the lowest: compounds 2, 3 and 1 (each within the scatter of the next, the first and the last beyond it).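

Among the compounds shown here, at this amine nitrogen in a ring, the earlier compounds carried only an aromatic ring directly on the nitrogen, and compound 3 shows that 4-fluorobenzyl keeps the number in the same range in this assay. Both a 1.2-fold higher number from compound 2 to compound 3 (0.06 log units; within the scatter) and a 1.8-fold lower number from compound 1 to compound 3 (0.26 log units; within the scatter) lie within the scatter, so compound 3 cannot be told apart from either compound, even though compound 1 and compound 2 are separated by a step beyond the scatter. No independent measurement is available here to account for this result.

The compounds shown leave open whether the fluorine on the benzyl ring contributes, as an unsubstituted benzyl or a 4-methoxybenzyl group would test. They also leave open how a carbonyl joining the aromatic ring to this nitrogen, as an amide, would read.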